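Solubility in the fused triazine series: cyclopropyl to difluoroethyl

The compounds below may be only part of what the source reports. "The series", "measured", "known", "first", "only" and "open" are said of these compounds alone.

Measured compounds:
- compound 1 `Cc1cc(Nc2ccc(S(F)(F)(F)(F)F)cc2)n2nc(C3CC3)nc2n1`: 16000 nM
- compound 2 `Cc1cc(Nc2cccc(Cl)c2)n2nc(C(C)(F)F)nc2n1`: 77000 nM

In a physicochemical assay for solubility, at pH 6.5 (a lower number here means a less soluble compound, a higher number a more soluble compound), compound 1 gives 16000 nM, the lower of the two numbers in hand. For the measured compounds named here, the only other measured member, compound 2, gives 77000 nM in this assay, a gap that lies beyond the scatter; compound 2 differs from compound 1 in two places at once, so no single step can be read from this pair.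

Compound 3 `Cc1cc(Nc2ccc(S(F)(F)(F)(F)F)cc2)n2nc(C(C)(F)F)nc2n1` has not yet been measured. It differs from compound 1 in one place, (1,1-difluoroethyl in place of cyclopropyl on an aromatic carbon). Compound 2 carries the same group that enters here, but alongside a different anilino substituent, so its higher value in this assay cannot be assigned to the group alone.

Going by the values given here, with no measured step for this change, the expectation for compound 3 is a small move, if any, in this assay, possibly upward, and the expected step is a 1.4-fold higher number from compound 1 to compound 3 (0.14 log units; within the scatter). Compound 3 is estimated at 22000 nM, with a range from 8000 nM to 60000 nM.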

Compound 3, solubility: 30000 nM
The estimate for compound 3 lay 1.4-fold (0.13 log units) below the measured number; the range from low to high includes it.
By their numbers in this assay, from the lowest: compounds 1 and 3 (each within the scatter of the next); then compound 2.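

In this assay, for the compounds shown here, the first comparison at this position that differs in one place only, 1,1-difluoroethyl in place of cyclopropyl on an aromatic carbon gives a 1.9-fold higher number from compound 1 to compound 3 (0.27 log units; within the scatter) on the shared core. The exchange of the three-membered carbon ring for the open 1,1-difluoroethyl group therefore produces no readable shift at this carbon, between two ring nitrogen atoms, and this holds for this one pair and this one anilino substituent only. Going by these compounds alone, nothing measured so far bears on the reason for this outcome.

Compound 2 gives 77000 nM and compound 3 gives 30000 nM with the same 1,1-difluoroethyl group, which leaves open how this exchange reads with the chlorine-bearing anilino substituent of compound 2. Also open, on these data alone, is how other groups at this carbon, such as an unfluorinated ethyl chain, an amine or a carboxylic acid, would read in this assay on the same core.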